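Mirror-Image Cyclopropanes and a Swap of Ester for Alcohol

A few compounds are considered here, and "the series" means these few. Any claim that something is new, unique, unknown or untested is made for them only; others in the source may bear on it.

Compound 2 `CCOC(=O)[C@]1(C(=O)NCc2ccc(C)cc2)C[C@H]1c1cc(OC)c(OC)c(OC)c1` and compound 1 `COc1cc([C@@H]2C[C@]2(CO)C(=O)NCc2ccc(C)cc2)cc(OC)c1OC` differ in one spot: hydroxymethyl in place of ethoxycarbonyl on a saturated ring carbon. In a functional assay on A549 cells (Homo sapiens) for cytotoxicity, read by MTT assay, with a stated time of 48 h (on this read-out higher numbers stand for weaker inhibition and lower numbers for stronger inhibition), compound 2 gives 13300 nM, and compound 1 gives 10500 nM, so the step is a 1.3-fold lower number from compound 2 to compound 1 (0.10 log units; within the scatter). Compound 3 `CCOC(=O)[C@@]1(C(=O)NCc2ccc(C)cc2)C[C@@H]1c1cc(OC)c(OC)c(OC)c1` is the mirror image of compound 2: the two compounds have the same atoms and bonds and differ only in configuration as drawn: 2 of 2 stereo elements differ (all stereocentres are inverted: mirror images); a stereocentre at a saturated ring carbon is drawn R in compound 2 and S in compound 3; a stereocentre at a saturated ring carbon is drawn S in compound 2 and R in compound 3. In this assay compound 3 gives only a limit of the assay, > 100000 nM. The step is an at least 7.5-fold higher number from compound 2 to compound 3 (0.87 log units; beyond the scatter), which rests on the fact that compounds 2 and 3 differ only in the configuration as drawn and on (the limit of > 100000 nM in this assay, at which 1 of the 3 values shown sits). Compound 4 `COc1cc([C@H]2C[C@@]2(CO)C(=O)NCc2ccc(C)cc2)cc(OC)c1OC` is not yet measured; it comes from compound 3 by the same change seen between compound 2 and compound 1: hydroxymethyl in place of ethoxycarbonyl on a saturated ring carbon. Since that change gave a 1.3-fold lower number from compound 2 to compound 1 (0.10 log units; within the scatter), the expectation is a similar small step, a number no higher from compound 3 to compound 4 (the limit leaves the size open). Compound 4 is thus estimated at 100000 nM.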

Compound 4, half-maximal inhibitory concentration: 63800 nM
For compound 4 the middle estimate is 1.6-fold (0.20 log units) above the measured one; the range from low to high includes it.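

In this assay, the same swap of ethoxycarbonyl for hydroxymethyl on the core of compound 3 gives a step (an at least 1.5-fold lower number from compound 3 to compound 4 (0.19 log units; that floor lies within the scatter)) that fits the small step seen on the mirror-image core. Compound 3 stands at a limit of the assay (> 100000 nM), and this is a limit, not a number. The change therefore carries over to the second core without any sign of a large rise in the number, but its true size there cannot be read, and neither can any gap between the two steps: the same change on two cores in this assay, a 1.3-fold lower number (0.10 log units; within the scatter) from compound 2 to compound 1 and an at least 1.5-fold lower number (0.19 log units; that floor lies within the scatter) from compound 3 to compound 4; the limit leaves it open whether they differ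

With hydroxymethyl on both cores, the mirror images remain apart (a 6.1-fold higher number from compound 1 to compound 4 (0.78 log units; beyond the scatter)). On these data alone, whether that gap would hold with an amine or a carboxylic acid on the saturated ring carbon stays open.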